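A few compounds are considered here, and "the series" means these few. Any claim that something is new, unique, unknown or untested is made for them only; others in the source may bear on it.

Working notes on the series. In a functional assay on DU-145 cells (Homo sapiens) for inhibition, read by trypan blue exclusion, with a stated time of 96 h (on this read-out lower numbers stand for stronger inhibition of growth and higher numbers for weaker inhibition of growth), compound 1 `O=C(/C(=C\c1c(O)cc(O)cc1O)Sc1ccccc1Br)c1ccc(Br)cc1` gives only a limit, > 100000 nM. Compound 2 `O=C(/C(=C\c1ccc(O)cc1O)Sc1ccccc1Br)c1ccc(Br)cc1` gives 50000 nM in this assay. Compound 3 `CN(C)c1ccc(/C=C(/Sc2ccccc2Br)C(=O)c2ccc(Br)cc2)cc1` likewise gives only a limit, > 100000 nM. Across the measured pairs the steps are an at least 2.0-fold lower number from compound 1 to compound 2 (0.30 log units; that floor lies within the scatter), an at least 2.0-fold higher number from compound 2 to compound 3 (0.30 log units; that floor lies within the scatter) and a step that the two limits leave unreadable from compound 1 to compound 3, and they are bounded by the limit of > 100000 nM in this assay, at which 2 of the 3 values shown sit. Compound 1 thus stands at the weak end of the numbers shown, with no number of its own.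

Compound 4 `Cc1ccc(S/C(=C/c2c(O)cc(O)cc2O)C(=O)c2ccc(Br)cc2)cc1` is still to be measured in this assay. From compound 1 it differs by 4-methylphenyl in place of 2-bromophenyl on a sulfur. Every measured step in the series changes the aryl on the double-bonded chain carbon, and none touches the group on the sulfur, so none of them bears on this change, and no size or direction can be drawn from them. The only anchor is the limit of compound 1, and the expectation is a step of a number no higher from compound 1 to compound 4 (the limit leaves the size open) that stays within the scatter. Compound 4 is therefore estimated at 100000 nM, in the range 30000 nM to 300000 nM, with a fair chance that this assay again reports only a limit.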

Compound 4, concentration for 50% growth inhibition: > 100000 nM
Compound 4 gave a limit, no number; the forecaster's own chance of this, stated with the estimate: 60%; the middle value lies on the limit itself.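

Compound 4 gives only a limit in this assay, as compound 1 does, so no step can be read between the two: the limit of > 100000 nM in this assay, at which 3 of the 4 values shown sit. The compounds shown leave open whether 4-methylphenyl in place of 2-bromophenyl on a sulfur changes growth inhibition at all.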